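The compounds below may be only part of what the source reports. "The series", "measured", "known", "first", "only" and "open" are said of these compounds alone.

Measured compounds:
compound 1 `CC1=C(C(=O)CC(C)C)C(c2ccco2)NC(=O)N1` — 240 nM
compound 2 `CC1=C(C(=O)CC(C)C)C(c2ccoc2)NC(=O)N1` — 1010 nM
compound 3 `CC1=C(c2ncc(C)o2)C(c2ccco2)NC(=O)N1` — 905 nM

In an assay on membranes from HEK293 cells for displacement of a labelled ligand from adenosine receptor A2b (Homo sapiens), read by scintillation counting, with a stated time of 30 min (on this read-out higher numbers stand for weaker inhibition and lower numbers for stronger inhibition), compound 1 gives the lowest of the three numbers. Its nearest neighbour is compound 3, reached by a 3.8-fold higher number from compound 1 to compound 3 (0.58 log units; beyond the scatter), and the furthest is compound 2, reached by a 4.2-fold higher number from compound 1 to compound 2 (0.62 log units; beyond the scatter). Both steps lie beyond the scatter, so compound 1 is the strongest inhibitor of the three in this assay.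

Compound 4 `CC1=C(C(=O)OCC2CCC2)C(c2ccco2)NC(=O)N1` has not yet been measured. It differs from compound 1 in one place: cyclobutylmethoxy in place of isobutyl on a carbonyl carbon. Within the data shown here, of the two measured steps, only the one from compound 1 to compound 3 touches the same part of the molecule, and there the change was a 3.8-fold higher number from compound 1 to compound 3 (0.58 log units; beyond the scatter), a modest weakening. The step from compound 1 to compound 2 concerns the furan and says little about the present change. Among the measured compounds shown here, no measured pair exchanges one substituent on the carbonyl carbon for another, so the direction can only be guessed from the fact that the single alteration at this end of the core so far raised the number. On that basis a modest rise is expected, amounting to a 1.9-fold higher number from compound 1 to compound 4 (0.27 log units; within the scatter). Compound 4 is therefore estimated at 450 nM in this assay, with a range from 130 nM to 1500 nM.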

Compound 4, inhibition constant: 561 nM
Compound 4: the middle estimate sits 1.2-fold (0.10 log units) below what was measured; measured number inside the range.
By their numbers in this assay, from the lowest: compound 1; then compounds 4, 3 and 2 (each within the scatter of the next).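

Compound 4 keeps the carbonyl and exchanges only the group on the carbonyl carbon, and in this assay replacing isobutyl with cyclobutylmethoxy gives a 2.3-fold higher number from compound 1 to compound 4 (0.37 log units; beyond the scatter), a modest step that lies beyond the scatter. Compound 3 had replaced the whole isobutylcarbonyl group, so compound 4 adds the finding that the number also responds to a change made on the carbonyl carbon while the carbonyl remains. Compound 1 still gives the lowest number of the four, but the exchange changes several things at once, bringing in a four-membered ring and an oxygen that counts as one hydrogen-bond acceptor, and this single step cannot separate them. No measurement shown here offers an explanation for the step.

The compounds shown leave open whether the oxygen or the ring accounts for the step, which a cyclobutylmethyl group without the oxygen or a plain methoxy group on the carbonyl carbon could help to separate. They also leave open how an amine at this carbon would read, and whether furan-3-yl would have the same effect when paired with cyclobutylmethoxy.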